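A few compounds are considered here, and "the series" means these few. Any claim that something is new, unique, unknown or untested is made for them only; others in the source may bear on it.

Measured in an in vivo ADME assay on the whole organism (plasma, strain Sprague-Dawley) for pharmacokinetics, with Rattus norvegicus as the target; a higher number here means faster removal of the compound, a lower number slower removal:
- Compound 1 `CN[C@@H](C)c1ccc(N2CC[C@H](NS(=O)(=O)c3ccc4cc(Cl)ccc4c3)C2=O)c(F)c1`: 1.6 mL/min/kg
- Compound 2 `O=C1[C@@H](NS(=O)(=O)c2ccc3cc(Cl)ccc3c2)CCN1c1ccc(C2CCCN2)cc1F`: 2.7 mL/min/kg
- Compound 3 `O=C1[C@@H](NS(=O)(=O)c2ccc3c(Cl)c[nH]c3c2)CCN1c1ccc(C2CCCN2)cc1F`: 1.3 mL/min/kg

Compound 2 cannot be separated from compound 1 in this assay, as the step shows: a 1.7-fold higher number from compound 1 to compound 2 (0.23 log units; within the scatter). It does stand clear of compound 3: a 2.1-fold lower number from compound 2 to compound 3 (0.32 log units; beyond the scatter). Compound 4 `O=C1[C@@H](NS(=O)(=O)c2ccc3cc(Cl)ccc3c2)CCN1c1ccc([C@H]2CCCN2)cc1F` is the next to be considered, and it differs from compound 2 as follows: the two compounds have the same atoms and bonds; at least one stereo element is drawn with a configuration in one of them and without one in the other: 1 of 2 stereo elements differ; a stereocentre at a saturated ring carbon is drawn without a configuration in compound 2 and R in compound 4. A stereocentre at a saturated ring carbon is drawn without a configuration in compound 2 and R in compound 4, while the atoms and bonds stay the same.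

Going by the values given here, no measured pair isolates a change of this kind. The first step above brought in the pyrrolidin-2-yl group and stayed within the scatter, and the second, at the sulfonyl sulfur, was modest. Neither points to a direction, so no shift beyond the scatter is expected. The expected step is a 1.1-fold lower number from compound 2 to compound 4 (0.03 log units; within the scatter). For compound 4 the estimated value is 2.5 mL/min/kg, with an expected range from 1.3 mL/min/kg to 4.8 mL/min/kg.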

Compound 4, clearance: 2.6 mL/min/kg
For compound 4 the middle estimate is 1.0-fold (0.02 log units) below the measured one; the measured number falls inside the stated range.
By their numbers in this assay, from the lowest: compounds 3, 1, 4 and 2 (each within the scatter of the next, the first and the last beyond it).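

Drawing the stereocentre at the saturated ring carbon as R gives a clearance that cannot be separated from that of compound 2 in this assay: a 1.0-fold lower number from compound 2 to compound 4 (0.02 log units; within the scatter). With the configuration now defined in both compounds, the exchange of 1-(methylamino)ethyl for pyrrolidin-2-yl also stays unresolved: a 1.6-fold higher number from compound 1 to compound 4 (0.21 log units; within the scatter). This is still not a comparison of R with S, because of one feature of the pair: the fact that one of compounds 2 and 4 is drawn with a defined configuration and the other without, at the place where they differ

Going by these compounds, what the S configuration at this carbon gives in this assay remains open. Also open, on these data alone, is whether a piperidin-2-yl group or a primary amine in place of pyrrolidin-2-yl would stand clear of compound 4, and how 3-chloro-1H-indol-6-yl on the sulfonyl sulfur behaves with the R configuration drawn.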